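A Third Methoxy Group on a Shared Core

The compounds below may be only part of what the source reports. "The series", "measured", "known", "first", "only" and "open" are said of these compounds alone.

Of the compounds shown here, three have been measured in a functional assay on BT-549 cells (Homo sapiens) for cytotoxicity, read by sulforhodamine B assay, with a stated time of 48 h, tested at 1 uM; a lower number here means a stronger effect, a higher number a weaker effect of the compound at the concentration tested. Compound 3 `COc1ccc(-c2cc(/C=C/C(=O)c3ccc(N)cc3)[nH]n2)cc1OC` gives 80%. Compound 1 `COc1cc(-c2cc(/C=C/C(=O)c3ccc(N)cc3)[nH]n2)cc(OC)c1OC` carries one more methoxy group, and in this assay compound 1 gives 73%; the step of a number 7 percentage points lower from compound 3 to compound 1 (within the scatter) corresponds to the change (methoxy in place of hydrogen on an aromatic carbon). Compound 2 `COc1ccc(C(=O)/C=C/c2cc(-c3cc(OC)c(OC)c(OC)c3)n[nH]2)cc1OC` differs from compound 1 at the carbonyl carbon, and in this assay compound 2 gives 76%, the step being a number 3 percentage points higher from compound 1 to compound 2 (within the scatter). How the core of compound 2 differs from the core of compound 3 is not broken down here.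

Compound 4 `COc1cc(C(=O)/C=C/c2cc(-c3cc(OC)c(OC)c(OC)c3)n[nH]2)cc(OC)c1OC` has not yet been measured. Among the measured compounds shown here, it arises from compound 2 by the change (methoxy in place of hydrogen on an aromatic carbon), which is the same change, with the same surroundings, as the one leading from compound 3 to compound 1. The step of a number 6 percentage points lower from compound 2 to compound 4 (within the scatter) is expected to be small, because the earlier step of a number 7 percentage points lower from compound 3 to compound 1 (within the scatter) stayed within the scatter and because compound 2 gives 76% as its starting point. Compound 4 is therefore estimated at 70% in this assay, with a likely range from 58% to 84%.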

Compound 4, a percentage reported as activity, at one concentration (the size of the read-out at that concentration, not a potency): 85%
Estimate against measurement, compound 4: 15 percentage points below; measured number above the stated range.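

Read in this assay, methoxy in place of hydrogen on an aromatic carbon gives a number 9 percentage points higher from compound 2 to compound 4 (within the scatter). The same change therefore does not carry over as one fixed step between these two cores, and the gap between its two outcomes is larger than the scatter allows: the same change on two cores in this assay, a number 7 percentage points lower (within the scatter) from compound 3 to compound 1 and a number 9 percentage points higher (within the scatter) from compound 2 to compound 4, 16 percentage points apart, beyond the scatter of two such steps

This does not show that the added methoxy has a real effect on either core, since each step taken alone stays within the scatter, and two cores at a single concentration establish no rule for the series and give no reason for the gap. The compounds shown leave open what a hydroxyl group or a chlorine atom would do in place of the hydrogen at this position, where only methoxy appears here. They also leave open whether the same change would follow either step on a third core, for example one carrying a carboxylic acid on the ring attached to the carbonyl carbon.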